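This account rests on a few compounds, and the source may have more. Where it says the series, first, only, none or still open, it means among the compounds named here.

Compound 1, `CCc1cc(C(C)=O)c(O)cc1OCCCCC#N`, gives 92%; compound 2, `CCCCCc1cc(C(C)=O)c(O)cc1OCCCCC#N`, gives 31%; compound 3, `CC(=O)c1cc(C=O)c(OCCCCC#N)cc1O`, gives 6%.

In an assay on isolated protein for inhibition of leukotriene B4 receptor 1 (Homo sapiens), tested at 10 uM (on this read-out higher numbers stand for more inhibition at the one concentration tested (going by the name of the read-out) and lower numbers for less inhibition), compound 1 stands highest of the three, with the nearest measured number reached by a number 61 percentage points lower from compound 1 to compound 2 (beyond the scatter) and the furthest by a number 86 percentage points lower from compound 1 to compound 3 (beyond the scatter). Compound 4, `CCc1cc(C(C)=O)c(O)cc1OCCCCCCSC`, differs from compound 1 at the far end of the chain: 2-(methylsulfanyl)ethyl in place of cyano on a saturated chain carbon, four bonds along the chain from an oxygen on an aromatic ring. Neither measured step touches this part of the molecule; both alter groups on the ring, so they offer no direct guide to a change at the chain terminus. The steps in this assay were large wherever compound 1 was altered, which makes it expected that compound 4 lands below compound 1, with a number 32 percentage points lower from compound 1 to compound 4 (beyond the scatter) as the estimated step. Compound 4 is therefore expected to show about 60%, between 20% and 92%.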

Compound 4, a percentage reported as inhibition, at one concentration (the size of the read-out at that concentration, not a potency): 71%
Beside the measured number, compound 4's estimate is 11 percentage points below it, within the range that was stated.
By their numbers in this assay, from the lowest: compound 3; then compound 2; then compound 4; then compound 1.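

In this assay, going by these compounds alone, the far end of the chain proves open to change: with 2-(methylsulfanyl)ethyl in place of cyano, the result is a number 21 percentage points lower from compound 1 to compound 4 (beyond the scatter) and this step is modest, whereas the earlier steps only altered groups on the ring. The nitrile is thus not needed for substantial inhibition at the one concentration tested, although compound 1 keeps the higher number. No measured evidence bears on the cause of this step.

Going by these compounds, whether a carboxylic acid or an amine at the chain end would retain inhibition stays open. So does whether the sulfur or the longer chain accounts for the step.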